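This account rests on a few compounds, and the source may have more. Where it says the series, first, only, none or still open, it means among the compounds named here.

Measured compounds:
Compound 1 `CC(C)(C)OC(=O)N1CCN(C(=O)c2cn(-c3ccc(C#N)cc3F)nn2)CC1` gives 4.21 nM in an assay on HEK293 cells for agonist activity at Glucose-dependent insulinotropic receptor (Homo sapiens), read by a luciferase reporter, with a stated time of 24 h; on this read-out higher numbers stand for an effect only at larger amounts of compound and lower numbers for an effect already at smaller amounts.
Compound 2 `CC(C)(C)OC(=O)N1CCC(OC(=O)c2cn(-c3ccc(C(F)(F)F)cc3)nn2)CC1` gives 10.4 nM in this assay.

Of these two numbers, compound 2 gives the higher one, and its distance to compound 1 lies beyond the usual scatter of this assay; compound 1 therefore acts at the smaller amount of the two. The two compounds differ in several places at once, so no single structural change can be tied to that gap.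

Compound 3 `CC(C)(C)OC(=O)N1CCC(OC(=O)c2cn(-c3ccc(C(F)(F)F)cc3Cl)nn2)CC1` is not yet measured. It differs from compound 2 in one place: chloro in place of hydrogen on an aromatic carbon. Among the compounds with values here, no measured pair shows this exact change, so the expectation for compound 3 rests only on compound 2 as its starting point. The step from compound 2 to compound 3 is expected to be small, a 1.5-fold lower number from compound 2 to compound 3 (0.17 log units; within the scatter), and may fall within the scatter. Compound 3 is therefore expected to give about 7 nM in this assay, with a range from 2.5 nM to 25 nM.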

Compound 3, half-maximal effective concentration: 11.1 nM
For compound 3 the middle estimate is 1.6-fold (0.20 log units) below the measured one; the range from low to high includes it.
By their numbers in this assay, from the lowest: compound 1; then compounds 2 and 3 (each within the scatter of the next).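

Chloro in place of hydrogen gives a 1.1-fold higher number from compound 2 to compound 3 (0.03 log units; within the scatter) in this assay, on an aromatic carbon that is ortho to a large group and meta to a trifluoromethyl group. Within the data shown here, this is the first single change that can be read on its own, since compound 1 and compound 2 differ in several places at once. Among these compounds, on the scaffold of compound 2, then, this carbon carries a chlorine atom with no step that can be told apart from repeat measurements. Nothing at hand gives a reason for this result.

One chlorine atom at one carbon says little about other groups there, so a methyl, a methoxy or an amine at this carbon remains an open case. Also open, from the compounds shown here alone, is whether chloro would give a similar step on the core of compound 1.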